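A few compounds are considered here, and "the series" means these few. Any claim that something is new, unique, unknown or untested is made for them only; others in the source may bear on it.

Of the compounds shown here, three have so far been measured in an assay on isolated protein for binding affinity to Alpha-1D adrenergic receptor (Rattus norvegicus), read by radioligand binding; a higher number here means a weaker inhibitor, a lower number a stronger inhibitor. Compound 1 `CCS(=O)(=O)Nc1cc(C2CCCCC2)cc2c1CCCC2c1c[nH]cn1` gives 447 nM, compound 2 `CS(=O)(=O)Nc1cccc2c1CCCCC2c1c[nH]cn1` gives 2510 nM, and compound 3 `O=S(=O)(Nc1cccc2c1CCCC2c1c[nH]cn1)C1CC1` gives 2690 nM. Compound 3 holds the highest of the three numbers; its value and that of compound 2 lie within the scatter of each other, while compound 1 sits beyond the scatter with the lower number. No two of the measured compounds differ in only one place, so no single step can be read from them.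

The next compound is compound 4 `COC(=O)Nc1cccc2c1CCCC2c1c[nH]cn1`, which has not yet been measured in this assay. It differs from compound 3 by methoxycarbonyl in place of cyclopropylsulfonyl on a nitrogen on an aromatic ring. Among the measured compounds shown here, none of the measured compounds carries a methoxycarbonyl on that nitrogen, so the data give no direct guide to the size of this exchange. The account therefore expects a step of a 1.7-fold higher number from compound 3 to compound 4 (0.22 log units; within the scatter), modest and toward a somewhat higher number, though a result within the scatter would not surprise. Compound 4 is estimated at 4500 nM, with a range from 1300 nM to 15000 nM.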

Compound 4, inhibition constant: 3020 nM
For compound 4 the middle estimate is 1.5-fold (0.17 log units) above the measured one; measured number inside the range.
By their numbers in this assay, from the lowest: compound 1; then compounds 2, 3 and 4 (each within the scatter of the next).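

In this assay, among the compounds shown here, methoxycarbonyl in place of cyclopropylsulfonyl on a nitrogen on an aromatic ring gives a 1.1-fold higher number from compound 3 to compound 4 (0.05 log units; within the scatter), the first single step that can be read. At this nitrogen, then, neither the sulfur nor the three-membered ring of the group that leaves is required to keep the number where it stands: a smaller group without a ring, with the same count of hydrogen-bond acceptors, reads the same within the scatter. No measurement at hand offers a reason for this result.

The compounds shown leave open whether a free amine, an acetyl group or a longer chain on that nitrogen would read alike. They also leave open whether the same exchange would read alike on the core of compound 1.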